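The compounds below may be only part of what the source reports. "The series", "measured", "known", "first", "only" and "open" are said of these compounds alone.

In an ADME assay on a cell-free system (plasma, Homo sapiens) for protein binding (a lower number here means a smaller unbound share, a higher number a larger unbound share of the compound), compound 1 (`CC(C)Cc1ccc(-c2cn(C)c3cc(C(=O)NS(C)(=O)=O)ccc23)cc1`) gives 0.001 as its reading. Compound 2 (`Cn1cc(-c2ccc(C(F)(F)F)cc2)c2cc(F)c(C(=O)NS(C)(=O)=O)cc21`) gives 0.002 as its reading, and the two numbers lie within the scatter of each other, so no order can be drawn between them. Compound 3 (`Cn1cc(-c2ccc(C(F)(F)F)cc2)c2ccc(C(=O)NS(C)(=O)=O)cc21`) has not yet been measured. It differs from compound 2 at one place only (hydrogen in place of fluoro on an aromatic carbon), with hydrogen in place of fluoro on an aromatic carbon, ortho to a (methylsulfonyl)carbamoyl group. Among the compounds with values here, no measured pair differs in one place only, so the data offer no direct precedent for this change. The starting point is compound 2 at 0.002 in this assay and no move beyond the scatter is expected, in either direction. The estimated step of no change at the digits printed from compound 2 to compound 3 (within the scatter) is accordingly expected to be small. For compound 3 the estimated value is 0.002 within an expected range from 0.001 to 0.004 for repeated readings.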

Compound 3, unbound fraction: < 0.001
Compound 3: only a limit was reported; the forecaster's own chance of this, stated with the estimate: 5%; middle value at least 2.0-fold (0.30 log units) from the limit.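

In this assay compound 3 gives < 0.001, which is a limit of the assay and not a number. With hydrogen in place of fluoro on an aromatic carbon, ortho to a (methylsulfonyl)carbamoyl group, the series gains its first readable single-place step, an at least 2.0-fold lower number from compound 2 to compound 3 (0.30 log units; that floor lies within the scatter), so the data do not establish a real change at this position, though the true size of the step is left open on the lower side. With trifluoromethyl in place of isobutyl on an aromatic carbon there is a number no higher from compound 1 to compound 3 (the limit leaves the size open), and the series now touches the end of the measurable range: the limit of < 0.001 in this assay, at which 1 of the 3 values shown sits.

How much the fluoro contributes at this aromatic carbon stays unresolved, since one side of the only readable step is a limit and a reading for compound 3 on a more sensitive scale is not among the data shown. Also open, from the compounds shown here alone, is whether a chloro or a methoxy on the same carbon, or an amine or a carboxylic acid in place of the trifluoromethyl, would give an unbound fraction clear of the limit.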